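Mirror-image change in a urea with two measured points

A few compounds are considered here, and "the series" means these few. Any claim that something is new, unique, unknown or untested is made for them only; others in the source may bear on it.

Two ureas have been measured so far. Compound 1 `Cc1ccccc1NC(=O)N[C@@H](C)c1ccccc1` and compound 2 `CCc1ccccc1NC(=O)N[C@H](C)c1ccccc1` share the same core and differ in the group on one aryl ring and in the configuration of the chain carbon. In an ADME assay on the whole organism with Oryza sativa as the target, tested at 0.1 uM (a higher number here means a weaker effect of the compound at the concentration tested, a lower number a stronger effect), compound 1 gives 100%, and in this assay compound 2 gives 101%. Compound 2 stands alongside compound 1: the two numbers lie within the usual scatter of each other and cannot be told apart, and both sit at the level that means no measurable effect.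

Compound 3 `CCc1ccccc1NC(=O)N[C@@H](C)c1ccccc1` is not yet measured. It differs from compound 2 as follows: the two compounds have the same atoms and bonds and differ only in configuration as drawn: 1 of 1 stereo elements differ; a stereocentre at a saturated chain carbon is drawn R in compound 2 and S in compound 3. Going by the values given here, no step between measured compounds of this kind has been recorded, and neither measured compound shows any effect, so the step of a number 1 percentage points lower from compound 2 to compound 3 (within the scatter) is expected to be none beyond the scatter. Compound 3 is expected to give 100%, in a range from 90% to 110%.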

Compound 3, a percentage reported as activity, at one concentration (the size of the read-out at that concentration, not a potency): 100%
The estimate for compound 3 equals the measured number at the digits printed; low and high end bracket the measured number.
By their numbers in this assay, from the lowest: compounds 1, 3 and 2 (each within the scatter of the next).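

In this assay, the configuration of the chain carbon can now be judged on its own, because a single feature separates this pair: the fact that compounds 2 and 3 differ only in the configuration as drawn The result is a number 1 percentage points lower from compound 2 to compound 3 (within the scatter), so drawing this stereocentre as R or S makes no readable difference here. Methyl in place of hydrogen on a saturated chain carbon bound to an aromatic carbon gives no change at the digits printed from compound 1 to compound 3 (within the scatter), so this change also leaves the read-out indistinguishable, with all three compounds at the level of no measurable effect.

Going by these compounds alone, because no compound here shows an effect, it remains open whether the configuration would matter in a urea that does show one. On these data alone, it is also open whether a larger change, such as a carboxylic acid or an amine on the aryl ring, would produce any effect at all.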